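Two Bis-Arylidene Analogues and an Unmeasured Dichlorophenyl Cousin

A few compounds are considered here, and "the series" means these few. Any claim that something is new, unique, unknown or untested is made for them only; others in the source may bear on it.

Measured compounds:
- compound 1 `COc1ccccc1/C=c1\c(=O)[nH]/c(=C/c2ccccc2Cl)c(=O)n1C`: 300 nM
- compound 2 `C=CCn1c(=O)/c(=C\c2ccc(F)c(Br)c2)[nH]c(=O)/c1=C\c1ccccc1OC`: "not active" (no number reported)
- compound 3 `C=CCn1c(=O)/c(=C\c2cc(OC)c(OC)c(OC)c2)[nH]c(=O)/c1=C\c1cccc(Br)c1`: "not active" (no number reported)

In a functional assay on Huh-7 cells (Homo sapiens) for cytotoxicity, read by CCK-8 assay, with a stated time of 72 h (a higher number here means a weaker inhibitor, a lower number a stronger inhibitor), compound 1 gives 300 nM. Compound 2 stands apart from it: in this assay compound 2 is reported as "not active" (no number reported), with no number attached. Compound 3 shares that fate, reported in this assay as "not active" (no number reported). So compound 2 cannot be placed on the scale at all; it only sits outside the range where a number is given, and no step between two measured compounds connects it to compound 1.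

Compound 4 `C=CCn1c(=O)/c(=C\c2cccc(Cl)c2Cl)[nH]c(=O)/c1=C\c1ccccc1OC` keeps the whole of compound 2 except for one part. The change is 2,3-dichlorophenyl in place of 3-bromo-4-fluorophenyl on a double-bonded chain carbon bound to an aromatic carbon. Within the data shown here, with no measured step to lean on, the expectation rests on compound 2 alone, which gave "not active" (no number reported) in this assay. The most likely outcome is that compound 4 also returns no number in this assay; if a number does appear, it is expected to be weak, estimated at 20000 nM with a range from 3000 nM to 100000 nM.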

Compound 4, half-maximal inhibitory concentration: 1200 nM
Beside the measured number, compound 4's estimate is 17-fold (1.22 log units) above it; measured number below the stated range.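

Compound 2 carries no number in this assay, and compound 4 differs from compound 1 in more than one place, so neither pair gives a readable step. As far as these compounds go, how far the 2,3-dichlorophenyl swap shifts potency stays open. No data on hand explain compound 4's result.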